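Stereochemistry of a trihydroxypipecolic acid

This account rests on a few compounds, and the source may have more. Where it says the series, first, only, none or still open, it means among the compounds named here.

Measured so far:
Compound 1, `O=C(O)[C@@H]1NCC=C[C@@H]1O`: 1.3%
Compound 2, `O=C(O)[C@H]1NC[C@H](O)[C@H](O)[C@H]1O`: 21%
Compound 3, `O=C(O)[C@H]1NC[C@@H](O)[C@@H](O)[C@@H]1O`: 3.8%

In an assay for inhibition of alpha-N-acetylgalactosaminidase (Gallus gallus), tested at 1000 uM (on this read-out lower numbers stand for less inhibition and higher numbers for more inhibition at the one concentration tested (going by the name of the read-out)), compound 2 gives the highest number of the three, with compound 3 closest and compound 1 furthest below it. The new compound 4, `O=C(O)[C@@H]1NC[C@H](O)[C@@H](O)[C@H]1O`, is related to compound 2 by the two compounds have the same atoms and bonds and differ only in configuration as drawn: 2 of 4 stereo elements differ; a stereocentre at a saturated ring carbon is drawn S in compound 2 and R in compound 4; a stereocentre at a saturated ring carbon is drawn S in compound 2 and R in compound 4. Going by the values given here, the only measured step that bears on such a change is a number 17.2 percentage points lower from compound 2 to compound 3 (beyond the scatter), a step that rests on (the fact that compounds 2 and 3 differ only in the configuration as drawn). Inverting two of the same centres is expected to lower the number in the same direction, if perhaps less fully. Compound 4 is therefore expected to give a step of a number 14 percentage points lower from compound 2 to compound 4 (beyond the scatter), landing at about 7%, within a range from 0% to 18%.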

Compound 4, a percentage reported as inhibition, at one concentration (the size of the read-out at that concentration, not a potency): 4%
Beside the measured number, compound 4's estimate is 3 percentage points above it, within the range that was stated.
By their numbers in this assay, from the lowest: compounds 1, 3 and 4 (each within the scatter of the next); then compound 2.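

In this assay, inverting two stereocentres does about as much as inverting three, giving a number 17 percentage points lower from compound 2 to compound 4 (beyond the scatter), while the two inverted forms stay level, with a number 0.2 percentage points higher from compound 3 to compound 4 (within the scatter). Among these three stereoisomers, only the configuration of compound 2 stands out, and two different sets of inverted centres end at similar low readings. The atoms stay the same, so the step comes from configuration alone: the fact that compounds 2 and 4 differ only in the configuration as drawn

Which of the two inverted centres carries the step stays open, since they change together here. Also open, going by these compounds, is whether a methyl ester in place of the carboxylic acid would keep the reading of compound 2.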